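From methyl to cyclohexyl on the shared core

A few compounds are considered here, and "the series" means these few. Any claim that something is new, unique, unknown or untested is made for them only; others in the source may bear on it.

Measured in a functional assay on HCT-116 cells (Homo sapiens) for inhibition, read by MTT assay, with a stated time of 96 h; a lower number here means a stronger inhibitor of growth, a higher number a weaker inhibitor of growth:
Compound 1 `CCCC(=O)SCCCCCCNC(=O)c1cc(-c2ccncc2)n[nH]1`: 23500 nM
Compound 2 `Cc1cc(C(=O)NCCCCCCS)[nH]n1`: > 50000 nM
Compound 3 `O=C(NCCCCCCS)c1cc(-c2ccc3ccccc3c2)n[nH]1`: > 50000 nM

The reading for compound 2 is a limit and not a number. Compound 2 thus stands at the limit of > 50000 nM in this assay, at which 2 of the 3 values shown sit. Compound 4 `O=C(NCCCCCCS)c1cc(C2CCCCC2)n[nH]1` changes one group: cyclohexyl in place of methyl on an aromatic carbon. A small shift towards stronger growth inhibition is expected in this assay, perhaps none beyond the scatter. The caution rests on compound 3, whose > 50000 nM is also a limit. The estimated change is an at least 1.2-fold lower number from compound 2 to compound 4 (0.09 log units; that floor lies within the scatter). For compound 4 the estimated value is 40000 nM, with an expected range from 15000 nM to 80000 nM.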

Compound 4, concentration for 50% growth inhibition: > 50000 nM
Compound 4 ended at the assay's limit (the forecaster's own chance of this, stated with the estimate: 60%); middle value at least 1.2-fold (0.09 log units) away from the limit.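

No step can be read from compound 2 to compound 4, as each reading is a limit and not a number. The compounds shown leave open whether cyclohexyl in place of methyl changes growth inhibition at all.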